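Pyridin-2-yl for Phenyl: Expected Reductase Inhibition

The source may hold more compounds than are shown below. What is called first, only, known or untested is meant among the compounds shown, and "the series" means these compounds.

Of the compounds shown here, three have been measured in an assay on isolated protein for inhibition of 3-hydroxy-3-methylglutaryl-coenzyme A reductase (Homo sapiens); on this read-out higher numbers stand for weaker inhibition and lower numbers for stronger inhibition. Compound 1 `Cc1nc(-c2ccc(F)cc2)c(-c2ccc(F)cc2)n1/C=C/[C@@H](O)C[C@@H](O)CC(=O)O` gives only a limit of the assay, < 7 nM, as the evidence notes (the limit of < 7 nM in this assay, at which 1 of the 3 values shown sits). Compound 2 `CC(C)c1nc(-c2cccc(S(C)(=O)=O)c2)c(-c2ccc(F)cc2)n1/C=C/[C@@H](O)C[C@@H](O)CC(=O)O` gives 8.7 nM in this assay. Compound 3 `CC(C)c1cc(-c2ccccc2)c(-c2ccc(F)cc2)n1/C=C/[C@@H](O)C[C@@H](O)CC(=O)O` gives 8.7 nM in this assay, level with compound 2 within the scatter. Compound 4 `CC(C)c1cc(-c2ccccn2)c(-c2ccc(F)cc2)n1/C=C/[C@@H](O)C[C@@H](O)CC(=O)O` differs from compound 3 by pyridin-2-yl in place of phenyl on an aromatic carbon. Among the compounds with values here, no step between measured compounds covers this change, so the expectation rests on compound 3 alone. In this assay the change is expected to give a step of a 1.1-fold higher number from compound 3 to compound 4 (0.06 log units; within the scatter), none beyond the scatter in either direction. Compound 4 is estimated at 10 nM, with a range from 4 nM to 30 nM.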

Compound 4, half-maximal inhibitory concentration: 8.7 nM
Compound 4: the middle estimate sits 1.1-fold (0.06 log units) above what was measured; low and high end bracket the measured number.
By their numbers in this assay, from the lowest: compounds 2, 3 and 4 (each within the scatter of the next). At a limit, below all of these: compound 1.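

In this assay, pyridin-2-yl in place of phenyl on this aromatic carbon gives no change at the digits printed from compound 3 to compound 4 (within the scatter). This is the first pair shown that isolates this position, and it shows that a ring with one hetero atom and one hydrogen-bond acceptor can replace the all-carbon ring here without a step beyond the scatter. Nothing on hand bears on why the value holds.

As far as these compounds go, whether pyridin-3-yl or pyridin-4-yl would match pyridin-2-yl here remains open. So does the effect of an amine or a carboxylic acid on this ring.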